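This account rests on a few compounds, and the source may have more. Where it says the series, first, only, none or still open, it means among the compounds named here.

Compound 1 `COc1cc(-n2ncnc2-c2ccccc2)cc(OC)c1OC` gives > 10000 nM (a limit)
Compound 2 `COc1cc(-n2ncnc2-c2ccc(OC(C)C)cc2)cc(OC)c1OC` gives 700 nM (a number)

Both results come from a functional assay on HL-60 cells (Homo sapiens) for antiproliferative activity, read by MTT assay, with a stated time of 72 h (on this read-out higher numbers stand for weaker inhibition and lower numbers for stronger inhibition), and are read there. Compound 1 sits at > 10000 nM in this test, which is a limit of the assay and not a number. For the measured compounds named here, compound 2, at 700 nM in this assay, therefore holds the only true number so far.

Compound 3 `COc1cc(-n2ncnc2-c2ccc(F)cc2)cc(OC)c1OC` differs from compound 2 in one place (fluoro in place of isopropoxy on an aromatic carbon), with fluoro in place of isopropoxy on an aromatic carbon, para to a large group. Going by the values given here, one measured step bears on this (an at least 14-fold lower number from compound 1 to compound 2 (1.15 log units; beyond the scatter)). It came with isopropoxy in place of hydrogen, and it is large and beyond the scatter. Compound 3 gives that isopropoxy up, though fluoro is not hydrogen, so much but perhaps not all of that step is expected to reverse. A clear move to weaker inhibition is therefore expected (a 5.7-fold higher number from compound 2 to compound 3 (0.76 log units; beyond the scatter)). The estimate for compound 3 is 4000 nM (expected range 1500 nM to 10000 nM).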

Compound 3, half-maximal inhibitory concentration: > 10000 nM
Compound 3: a limit, no number (the forecaster's own chance of this, stated with the estimate: 35%); middle value at least 2.5-fold (0.39 log units) from the limit.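

In this assay compound 3 gives > 10000 nM, which is a limit of the assay and not a number. Putting fluoro in place of isopropoxy on this aromatic carbon gives an at least 14-fold higher number from compound 2 to compound 3 (1.15 log units; beyond the scatter), so among these compounds only the isopropoxy group yields a measurable value, and a substituent here does not by itself bring one. How compound 3 compares with compound 1, which carries hydrogen at this place, cannot be read, because both values are limits: the limit of > 10000 nM in this assay, at which 2 of the 3 values shown sit.

Going by these compounds, it remains open whether the oxygen or the carbon chain of isopropoxy carries the gain, a question that methoxy or a plain isopropyl group could help settle. On these data alone, how an amine or a carboxylic acid would behave at this place is also open.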